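A few compounds are considered here, and "the series" means these few. Any claim that something is new, unique, unknown or untested is made for them only; others in the source may bear on it.

Measured compounds:
- Compound 1 `COc1ccc(Nc2c(NCCCCCC(=O)NO)c(=O)c2=O)cc1` gives, in an ADME assay on cells (Hepatocyte, Homo sapiens) for pharmacokinetics, read by LC-MS, with a stated time of 90 min, tested at 1 uM (a higher number here means faster removal of the compound, a lower number slower removal), < 4.7 uL/min; this is a limit of the assay, not a number.
- Compound 2 `O=C(CCCCCNc1c(Nc2ccc(C(F)(F)F)cc2)c(=O)c1=O)NO` gives in this assay 11 uL/min.
- Compound 3 `COc1ccc(Nc2c(NC(C)CCCCC(=O)NO)c(=O)c2=O)cc1` gives in this assay 7.1 uL/min.

Compound 2 differs from compound 1 by trifluoromethyl in place of methoxy on an aromatic carbon. That change made an at least 2.3-fold higher number from compound 1 to compound 2 (0.36 log units; beyond the scatter); the step is known only as a floor because compound 1 sits at the limit of < 4.7 uL/min in this assay, at which 1 of the 3 values shown sits. Compound 3 differs from compound 1 in its core by methyl in place of hydrogen on a saturated chain carbon bound to a nitrogen on an aromatic ring and a saturated chain carbon, and that change made an at least 1.5-fold higher number from compound 1 to compound 3 (0.17 log units; that floor lies within the scatter). Compound 3 and compound 2 are within the scatter of each other.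

Compound 4 `CC(CCCCC(=O)NO)Nc1c(Nc2ccc(C(F)(F)F)cc2)c(=O)c1=O` has not yet been measured in this assay. It differs from compound 3 by trifluoromethyl in place of methoxy on an aromatic carbon, the same change as from compound 1 to compound 2, made on the core of compound 3 rather than that of compound 1. Since the earlier step gave an at least 2.3-fold higher number from compound 1 to compound 2 (0.36 log units; beyond the scatter) and compound 3 starts at 7.1 uL/min, a rise of similar size is expected, so the estimated step is a 2.5-fold higher number from compound 3 to compound 4 (0.40 log units; beyond the scatter). Compound 4 is estimated at 18 uL/min, likely between 9 uL/min and 36 uL/min.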

Compound 4, intrinsic clearance in a liver preparation (reported as CLH), per the amount of preparation that the assay uses: 21 uL/min
Compound 4: middle estimate off by 1.2-fold (0.07 log units), on the low side; low and high end bracket the measured number.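

In this assay, trifluoromethyl in place of methoxy gave a 3.0-fold higher number from compound 3 to compound 4 (0.47 log units; beyond the scatter), and the same change also raised the number on the core of compound 1, so its direction carried from one core to the other: the same change on two cores in this assay, an at least 2.3-fold higher number (0.36 log units; beyond the scatter) from compound 1 to compound 2 and a 3.0-fold higher number (0.47 log units; beyond the scatter) from compound 3 to compound 4; the limit leaves it open whether they differ

Methyl in place of hydrogen on the chain gave a 1.9-fold higher number from compound 2 to compound 4 (0.28 log units; within the scatter), so on this core it shows no clear effect, and its step on the other core does not establish one either: the same change on two cores in this assay, an at least 1.5-fold higher number (0.17 log units; that floor lies within the scatter) from compound 1 to compound 3 and a 1.9-fold higher number (0.28 log units; within the scatter) from compound 2 to compound 4; the limit leaves it open whether they differ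

On these data alone, compound 1 gives < 4.7 uL/min, which is a limit and not a number, so the size of each change on its core stays unknown, and two cores cannot show that either change would behave alike on a third.

The compounds shown leave open whether a nitrile or a chlorine atom in place of methoxy on the aromatic ring would raise the number as trifluoromethyl does. They also leave open whether an ethyl group in place of the methyl, or a longer chain, would produce a step beyond the scatter.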